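The source may hold more compounds than are shown below. What is called first, only, known or untested is meant among the compounds shown, and "the series" means these compounds.

Measured in a functional assay on HCT-116 cells (Homo sapiens) for inhibition, with a stated time of 72 h; on this read-out lower numbers stand for stronger inhibition and higher numbers for weaker inhibition:
- compound 1 `COc1ccccc1-c1ccc(CNc2nc(NC3CCC(N)CC3)nc3c2ncn3C2CCCC2)cc1`: 430 nM
- compound 2 `NC1CCC(Nc2nc(NCc3ccc(-n4cccn4)cc3)c3ncn(C4CCCC4)c3n2)CC1`: 320 nM
- compound 3 `NC1CCC(Nc2nc(NCc3ccc(-c4cccc(F)c4)nc3)c3ncn(C4CCCC4)c3n2)CC1`: 74 nM

Compound 3 holds the lowest of the three numbers, and its value lies beyond the scatter of both others.

The next compound to consider is compound 4 `NC1CCC(Nc2nc(NCc3ccc(-c4ccccc4O)nc3)c3ncn(C4CCCC4)c3n2)CC1`, which carries 2-hydroxyphenyl in place of 3-fluorophenyl on an aromatic carbon. This carbon belongs to a six-membered aromatic ring with 1 nitrogen, next to the ring nitrogen and para to a large group: 2-hydroxyphenyl in place of 3-fluorophenyl on an aromatic carbon.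

Going by the values given here, only one measured step exchanges a group on an aromatic carbon: a 1.3-fold lower number from compound 1 to compound 2 (0.13 log units; within the scatter), with 1H-pyrazol-1-yl in place of 2-methoxyphenyl. That step stays within the scatter, but it sits on a ring without the ring nitrogen and does not involve either group in the present change. It is therefore only weak support for expecting a small effect. Compound 1, with its 2-methoxyphenyl group, has the closest group to 2-hydroxyphenyl and reads 430 nM, but it differs from compound 4 in more than one place. That value gives only a slight lean towards a higher number.

The expected change is a 1.6-fold higher number from compound 3 to compound 4 (0.21 log units; within the scatter), with wide uncertainty. For compound 4 the estimated value in this assay is 120 nM, with an expected range of 40 nM to 360 nM.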

Compound 4, half-maximal inhibitory concentration: 35 nM
Compound 4: the middle estimate sits 3.4-fold (0.54 log units) above what was measured, outside the stated range (below it).
By their numbers in this assay, from the lowest: compound 4; then compound 3; then compounds 2 and 1 (each within the scatter of the next).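

In this assay, 2-hydroxyphenyl in place of 3-fluorophenyl, on an aromatic carbon next to the ring nitrogen and para to a large group, gives a 2.1-fold lower number from compound 3 to compound 4 (0.33 log units; beyond the scatter), a modest step. The exchange of one aryl group for another at this carbon therefore moves the read-out beyond the scatter, whereas a 1.3-fold lower number from compound 1 to compound 2 (0.13 log units; within the scatter) stays within it, with different groups on a ring without the ring nitrogen, so that earlier step does not carry over to this position. The entering group has a hydrogen-bond donor and acceptor that the leaving group lacks, but no measurement shown links this difference, or anything else, to the step.

The compounds shown do not separate the contribution of the hydroxyl from that of the phenyl ring carrying it; a plain phenyl group at this carbon, or an amine in place of the hydroxyl, would bear on that question. Going by these compounds alone, they also include no pair with the same aryl group on rings with and without the ring nitrogen, so the part played by that nitrogen remains open.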